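This account rests on a few compounds, and the source may have more. Where it says the series, first, only, none or still open, it means among the compounds named here.

Two compounds of this series carry numbers in an assay on membranes from lung (Cavia porcellus) for binding affinity to cysteinyl leukotriene receptor (Homo sapiens); a higher number here means a weaker inhibitor, a lower number a stronger inhibitor. Compound 1 `O=C(O)CC1CCCC1Cc1ccc(OCc2ccc3ccccc3n2)cc1` gives 100 nM in this assay. Compound 2 `c1cc(OCCCc2nnn[nH]2)cc(OCc2ccc3ccccc3n2)c1` gives 42 nM in this assay and so stands lowest of the two, with compound 1 the nearest number, beyond the scatter. Compound 3 `CC(Cc1cccc(OCc2ccc3ccccc3n2)c1)CC(C)C(=O)O` is the next to be measured; it differs from compound 2 by 4-carboxy-2-methylpentyl in place of 3-(1H-tetrazol-5-yl)propoxy on an aromatic carbon. Among the measured compounds shown here, no step between measured compounds is available to calibrate this change. A modest loss is expected, the step from compound 2 to compound 3 estimated at a 3.6-fold higher number from compound 2 to compound 3 (0.55 log units; beyond the scatter), because compound 1 with a carboxy group sits at 100 nM. Compound 3 is therefore expected near 150 nM, between 40 nM and 600 nM.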

Compound 3, inhibition constant: 24 nM
Compound 3: the middle estimate sits 6.3-fold (0.80 log units) above what was measured; measured number below the stated range.
By their numbers in this assay, from the lowest: compounds 3 and 2 (each within the scatter of the next); then compound 1.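

In this assay, 4-carboxy-2-methylpentyl in place of 3-(1H-tetrazol-5-yl)propoxy gives a 1.8-fold lower number from compound 2 to compound 3 (0.24 log units; within the scatter), so the two groups cannot be told apart here. On this aromatic carbon, meta to a large group, a chain without a ring and ending in a carboxy group therefore serves as well as the tetrazole-bearing chain. No measured evidence accounts for this result. The exchange alters the whole chain at once, so the contribution of each part stays unresolved. On these data alone, whether the methyl branches matter remains open, as does how an unbranched chain ending in a carboxylic acid or a primary amide would read.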